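Inverting the stereocentre of compound 1

This account rests on a few compounds, and the source may have more. Where it says the series, first, only, none or still open, it means among the compounds named here.

The measured compounds:
compound 1, `CC(C)[C@@H](C(=O)Nc1ccc(C(=O)Nc2ccccc2N)cc1)c1ccccc1`, giving 9% in an assay on isolated protein for inhibition of histone deacetylase 5 (Homo sapiens), tested at 1 uM; a higher number here means more inhibition at the concentration tested (going by the name of the read-out), a lower number less inhibition;
compound 2, `CC(C)(C(=O)Nc1ccc(C(=O)Nc2ccccc2N)cc1)c1ccccc1`, giving 0%;
compound 3, `CC(C)[C@@H](C(=O)Nc1ccc(C(=O)Nc2ccc(C(F)(F)F)cc2N)cc1)c1ccccc1`, giving 0%.

Within the data shown here, compound 1 carries the highest of the three numbers in this assay, but neither gap is meaningful: compound 2 sits 0%, and the one counted step, a number 9 percentage points lower from compound 1 to compound 3 (within the scatter), is itself inside the scatter. All three numbers lie close to the bottom of the scale at the concentration tested.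

Compound 4, `CC(C)[C@H](C(=O)Nc1ccc(C(=O)Nc2ccccc2N)cc1)c1ccccc1`, is the mirror-image partner of compound 1: the two compounds have the same atoms and bonds and differ only in configuration as drawn: 1 of 1 stereo elements differ; a stereocentre at a saturated chain carbon is drawn R in compound 1 and S in compound 4. Among the measured compounds shown here, none of the measured steps bears on this change. The step to compound 3 concerns a trifluoromethyl in place of hydrogen on an aromatic carbon, and the gap between compound 1 and compound 2 concerns a chain carbon that in compound 2 carries two methyls and therefore has no stereocentre at all. Nothing here tells how the two configurations differ in this assay, and the starting value of compound 1 leaves almost no room downward.

Compound 4 is therefore expected to stay near the baseline, with a number 4 percentage points lower from compound 1 to compound 4 (within the scatter) as the estimated step. The estimate for compound 4 is 5%, within 0% to 20%.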

Compound 4, a percentage reported as inhibition, at one concentration (the size of the read-out at that concentration, not a potency): 0%
The estimate for compound 4 lay 5 percentage points above the measured number, within the range that was stated.
By their numbers in this assay, from the lowest: compounds 2, 3, 4 and 1 (each within the scatter of the next).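

In this assay, among these compounds, the stereocentre at the saturated chain carbon now has a direct reading that none of the earlier compounds gave: a number 9 percentage points lower from compound 1 to compound 4 (within the scatter), so the two drawn configurations cannot be told apart there. The comparison speaks to the stereocentre and to nothing else, because of one plain fact: the fact that compounds 1 and 4 differ only in the configuration as drawn. It was made close to the bottom of the scale, so it shows no preference for either configuration, but it also cannot show that configuration is without consequence for this series.

Going by these compounds, what remains open is whether the two configurations would separate in a compound of this series with a clear reading in this assay, well above the baseline. Also open, on these data alone, is how the chain carbon would read with an amine or a hydroxyl group in place of its hydrogen, and whether either configuration of such a compound would then rise beyond the scatter.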